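The source may hold more compounds than are shown below. What is called first, only, known or untested is meant among the compounds shown, and "the series" means these compounds.

Of the compounds shown here, two have been measured in a functional assay on the whole organism (artery, strain albino) with Rattus norvegicus as the target, with a stated time of 15 min, at a dose of 10 mg/kg by the oral route; on this read-out higher numbers stand for more inhibition at the one dose given (going by the name of the read-out) and lower numbers for less inhibition. Compound 1 `CC1=C(C(=O)Nc2ccc(F)cc2)C(c2ccc([N+](=O)[O-])cc2)N=C(SCc2ccc(Cl)cc2)N1` gives 3.6%, and compound 2 `CC1=C(C(=O)Nc2ccc([N+](=O)[O-])cc2)C(c2ccc(Br)cc2)N=C(SCc2ccccc2)N1` gives 2.1%; the two numbers lie within the scatter of each other, so compound 2 stands alongside compound 1 rather than apart from it. Compound 3 `CC1=C(C(=O)Nc2ccc([N+](=O)[O-])cc2)C(c2ccc(Br)cc2)N=C(SCc2ccc(F)cc2)N1` has not been measured and differs from compound 2 by fluoro in place of hydrogen on an aromatic carbon. Going by the values given here, no measured pair shows this change, and compound 1, whose benzylsulfanyl group also carries a halogen, gives only 3.6%. The expected step is a number 0.9 percentage points higher from compound 2 to compound 3 (within the scatter), none beyond the scatter. For compound 3 the estimate in this assay is 3%, between -5% and 12%.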

Compound 3, a percentage reported as inhibition, in the whole organism at one dose (the size of the read-out at that dose, not a potency): 2.6%
Estimate against measurement, compound 3: 0.4 percentage points above, within the range that was stated.
By their numbers in this assay, from the lowest: compounds 2, 3 and 1 (each within the scatter of the next).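

Phenyl to 4-fluorophenyl on the benzylsulfanyl group gives the first single-change pair in this series. In this assay the change reads as a number 0.5 percentage points higher from compound 2 to compound 3 (within the scatter), so fluoro at this place, para to a large group, brings no separation on this read-out at the one oral dose. Nothing available bears on the reason for this result.

On these data alone, whether an amine or a carboxylic acid in place of the fluoro would read differently stays open. So does a longer chain in place of benzyl.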